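Swapping isobutyl for a trifluoromethylphenyl ring on a shared core

A few compounds are considered here, and "the series" means these few. Any claim that something is new, unique, unknown or untested is made for them only; others in the source may bear on it.

Of the compounds shown here, three sharing one core have been measured in an ADME assay on HepG2 cells (Homo sapiens) for cytotoxicity, read by luminescence, CellTiter-Glo and ATP content, with a stated time of 72 h; a higher number here means that more compound is needed for the effect, a lower number that less compound is needed. Compound 1 `COc1ccc(-c2ccc3c(NCCCNCc4cccc(OC)c4O)ccnc3c2)cc1` gives 1600 nM, compound 2 `COc1cccc(CNCCCNc2ccnc3cc(Cc4ccc(C#N)cc4)ccc23)c1O` gives 7150 nM, and compound 3 `COc1cccc(CNCCCNc2ccnc3cc(CC(C)C)ccc23)c1O` gives 2920 nM. Compound 3 thus sits second highest of the three, close to compound 1 and further from compound 2. Among the compounds with values here, the steps that bear on the new change are a 1.8-fold higher number from compound 1 to compound 3 (0.26 log units; within the scatter) and a 2.4-fold lower number from compound 2 to compound 3 (0.39 log units; beyond the scatter), with a 4.5-fold higher number from compound 1 to compound 2 (0.65 log units; beyond the scatter) showing how far two aryl-bearing analogues can differ. Compound 4 `COc1cccc(CNCCCNc2ccnc3cc(-c4ccc(C(F)(F)F)cc4)ccc23)c1O` is reached from compound 3 by the change (4-(trifluoromethyl)phenyl in place of isobutyl on an aromatic carbon). Since compound 3 and compound 1 sit within the scatter of each other, and since compound 4 carries an aryl group like compound 1, only a small step in this assay is expected, if any, likely toward a lower number. The estimate for compound 4 is 2000 nM, with a range from 800 nM to 5000 nM. That estimate corresponds to an expected step of a 1.5-fold lower number from compound 3 to compound 4 (0.16 log units; within the scatter).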

Compound 4, half-maximal effective concentration: 2210 nM
Compound 4: middle estimate off by 1.1-fold (0.04 log units), on the low side; measured number inside the range.
By their numbers in this assay, from the lowest: compounds 1, 4 and 3 (each within the scatter of the next); then compound 2.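

In this assay, the step of a 1.3-fold lower number from compound 3 to compound 4 (0.12 log units; within the scatter) shows that this aromatic carbon carries the 4-(trifluoromethyl)phenyl ring with its 10 heavy atoms and the smaller isobutyl group without a separable change in the number. The step of a 1.4-fold higher number from compound 1 to compound 4 (0.14 log units; within the scatter) adds that trifluoromethyl and methoxy on the outer ring cannot be told apart here either. With the step of a 3.2-fold lower number from compound 2 to compound 4 (0.51 log units; beyond the scatter) as well, compound 2 stands apart from each of the other three, and these numbers now mark out one group of three compounds plus that single outlier.

Still open, on these data alone, is whether compound 2 stands apart through its whole 4-cyanobenzyl group or its nitrile alone, and whether an amine or a carboxylic acid on this carbon would leave the number within that group. Nothing available here explains these numbers.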